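This account rests on a few compounds, and the source may have more. Where it says the series, first, only, none or still open, it means among the compounds named here.

Working notes on the series in a functional assay on the whole organism for antagonist activity, with Mus musculus as the target, in the maximal electroshock model; a lower number here means that less compound is needed, a higher number that more compound is needed for the effect.

Compound 1 `COC(=O)NC1=NC(c2ccccc2C)CN1` gives 55 mg/kg. Compound 2 `COC(=O)NC1=NC(c2ccccc2F)CN1` gives 54 mg/kg, and compound 3 `COC(=O)NC1=NC(c2ccccc2Br)CN1` gives 62 mg/kg. Within this set compound 1 stands second highest of the three numbers, but the spread is small: the step of a 1.0-fold lower number from compound 1 to compound 2 (0.01 log units; within the scatter), the step of a 1.1-fold higher number from compound 1 to compound 3 (0.05 log units; within the scatter) and the step of a 1.1-fold higher number from compound 2 to compound 3 (0.06 log units; within the scatter) are all within the scatter, so the three measured compounds cannot be ordered against one another on these numbers.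

Compound 4 `COC(=O)NC1=NC(c2ccccc2C)CN1C` is the next compound to be measured. It differs from compound 1 by methyl in place of hydrogen on an amine nitrogen in a ring. Among the measured compounds shown here, none of the measured steps bears directly on this change: every step so far exchanges one substituent for another on an aromatic carbon, and the ring amine nitrogen has carried hydrogen in all three measured compounds. For the measured compounds named here, the only guidance is that the three exchanges on the aromatic carbon left the number essentially unchanged, which says nothing about a change at the ring nitrogen.

Going by the values given here, with no step on record for this position, the working expectation for compound 4 is a number close to that of compound 1, with a wide range to allow for an unmeasured kind of change; the estimate is 65 mg/kg, between 30 mg/kg and 150 mg/kg, corresponding to an expected step of a 1.2-fold higher number from compound 1 to compound 4 (0.07 log units; within the scatter).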

Compound 4, dose for half-maximal effect: 68 mg/kg
The estimate for compound 4 lay 1.0-fold (0.02 log units) below the measured number, within the range that was stated.
By their numbers in this assay, from the lowest: compounds 2, 1, 3 and 4 (each within the scatter of the next).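

Methyl in place of hydrogen on the amine nitrogen in the ring gives, in this assay, a 1.2-fold higher number from compound 1 to compound 4 (0.09 log units; within the scatter), the first reading at this position in the series. Among the compounds shown here, the hydrogen on this ring nitrogen is therefore not needed to keep the number in the range of the earlier compounds, at least with the methyl group on the aromatic ring of compound 1, and this position joins the aromatic carbon as a place where a single small exchange leaves the number within the scatter. No measurement in hand bears on the reason for this result.

As far as these compounds go, what a longer chain such as propyl, a benzyl group or an acetyl group would do on this ring nitrogen remains open, since methyl alone marks how much room the position allows in this whole-organism read-out. Also open, from the compounds shown here alone, is whether the same methyl exchange would give a comparably small step with the fluoro group of compound 2 or the bromo group of compound 3 on the aromatic ring.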